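A few compounds are considered here, and "the series" means these few. Any claim that something is new, unique, unknown or untested is made for them only; others in the source may bear on it.

Measured compounds:
Compound 1 `N#Cc1ccc(Cc2cnc(CCc3ccc(-c4ccccc4C(=O)O)cc3)[nH]2)cc1`: 723 nM
Compound 2 `N#Cc1cccc(Cc2cnc(CCc3ccc(-c4ccccc4C(=O)O)cc3)[nH]2)c1`: 20 nM
Compound 3 `O=C(O)c1ccccc1-c1ccc(CCc2ncc(CCC3CCCCC3)[nH]2)cc1`: 33 nM

In an in vitro functional assay on cells for agonist activity at Bombesin receptor subtype-3 (Mus musculus), read by luminescence and calcium flux (a higher number here means that more compound is needed for the effect, a lower number that less compound is needed), compound 3 has the second highest of the three numbers. Its nearest neighbour is compound 2, as a 1.7-fold higher number from compound 2 to compound 3 (0.22 log units; within the scatter); its furthest is compound 1, as a 22-fold lower number from compound 1 to compound 3 (1.34 log units; beyond the scatter).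

Compound 4 `CCC(C)(CC)Cc1cnc(CCc2ccc(-c3ccccc3C(=O)O)cc2)[nH]1` differs from compound 3 in one place: 1-ethyl-1-methylpropyl in place of cyclohexylmethyl on a saturated chain carbon bound to an aromatic carbon. Going by the values given here, no measured step exchanges one saturated group for another; the two large steps, a 36-fold lower number from compound 1 to compound 2 (1.56 log units; beyond the scatter) and a 22-fold lower number from compound 1 to compound 3 (1.34 log units; beyond the scatter), both start from the same 4-cyanophenyl group, while the step between compound 2 and compound 3 shows that two rather different groups at this position can give similar numbers. The expected step in this assay is therefore small, a 1.4-fold higher number from compound 3 to compound 4 (0.13 log units; within the scatter), and compound 4 is estimated at 45 nM, in the range 15 nM to 150 nM.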

Compound 4, half-maximal effective concentration: 30 nM
Compound 4: the middle estimate sits 1.5-fold (0.18 log units) above what was measured; the range from low to high includes it.
By their numbers in this assay, from the lowest: compounds 2, 4 and 3 (each within the scatter of the next); then compound 1.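

In this assay, the open-chain 1-ethyl-1-methylpropyl group, which has no ring, gives a number matching that of cyclohexylmethyl (a 1.1-fold lower number from compound 3 to compound 4 (0.04 log units; within the scatter)) and that of 3-cyanophenyl (a 1.5-fold higher number from compound 2 to compound 4 (0.18 log units; within the scatter)). A ring is therefore not required at this place in these compounds, and 4-cyanophenyl alone stands apart (a 24-fold lower number from compound 1 to compound 4 (1.38 log units; beyond the scatter)). Nothing measured here accounts for this.

From the compounds shown here alone, it remains open whether a much smaller group such as methyl, a longer chain, or a chain carrying an amine would keep numbers in this range.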